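This account rests on a few compounds, and the source may have more. Where it says the series, first, only, none or still open, it means among the compounds named here.

In a functional assay on BXPC-3 cells (Homo sapiens) for inhibition, read by MTT assay, with a stated time of 7 days (a lower number here means a stronger inhibitor, a higher number a weaker inhibitor), compound 2 `CCN(CC)S(=O)(=O)c1ccc(S(=O)(=O)N2CCC[C@@H](C(=O)N[C@H]3CCOC3)C2)cc1` gives 5270 nM, the lower of the two numbers seen so far. Among the compounds with values here, its nearest neighbour, compound 1 `CCN(CC)S(=O)(=O)c1ccc(S(=O)(=O)N2CCC[C@@H](C(=O)NC3COC3)C2)cc1`, gives 13800 nM in this assay, and the one measured step, a 2.6-fold lower number from compound 1 to compound 2 (0.42 log units; beyond the scatter), came from the change of the ring on the amide-type nitrogen.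

Compound 3 `CCN(CC)S(=O)(=O)c1ccc(S(=O)(=O)N2CCC[C@@H](C(=O)N3CCC(COC)CC3)C2)cc1` takes the next step from compound 2: 4-(methoxymethyl)piperidin-1-yl in place of (oxolan-3-yl)amino on a carbonyl carbon. Here the amide hydrogen is gone and the ring is now joined through its own nitrogen. Within the data shown here, the only measured step, from compound 1 to compound 2, enlarged the ring on that nitrogen and moved the number modestly; no measured step alters the nitrogen itself, so nothing seen so far speaks directly to the change in compound 3. On that basis a step in this assay no larger than the scatter is expected, with the direction open, and compound 3 is expected to give about 6500 nM, somewhere between 1800 nM and 24000 nM, which would mean a step of a 1.2-fold higher number from compound 2 to compound 3 (0.09 log units; within the scatter).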

Compound 3, half-maximal inhibitory concentration: 1360 nM
Compound 3: the middle estimate sits 4.8-fold (0.68 log units) above what was measured, outside the stated range (below it).
By their numbers in this assay, from the lowest: compound 3; then compound 2; then compound 1.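

In this assay the place on the carbonyl carbon proved able to take more than a change of ring size: a tertiary amide carrying 4-(methoxymethyl)piperidin-1-yl, with no amide hydrogen, was not merely tolerated but gave a lower number (a 3.9-fold lower number from compound 2 to compound 3 (0.59 log units; beyond the scatter)). Within the data shown here, measured against the oxetan-3-yl amide, the same replacement gave the largest step so far (a 10-fold lower number from compound 1 to compound 3 (1.01 log units; beyond the scatter)), which exceeds the earlier ring enlargement (a 2.6-fold lower number from compound 1 to compound 2 (0.42 log units; beyond the scatter)) and shows that this position can move the number substantially. No measurement given here accounts for the improvement, and the change alters the ring, its link to the carbonyl carbon, the amide hydrogen and the side chain all at once.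

Which of these parts carries the step remains open: a methyl group on the amide nitrogen of compound 2 would address the amide hydrogen alone, while an unsubstituted piperidin-1-yl would address the methoxymethyl chain. Whether that chain's oxygen matters, or whether an ethyl chain or a morpholine ring would serve as well, also remains unsettled.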